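The source may hold more compounds than are shown below. What is called first, only, known or untested is meant among the compounds shown, and "the series" means these compounds.

Measured in an ADME assay on the whole organism (Rattus norvegicus, strain Sprague-Dawley) for pharmacokinetics, at a dose of 0.5 mg/kg by the intravenous route; on this read-out higher numbers stand for fast clearance and lower numbers for slow clearance:
- compound 1 `C[C@H](Nc1ncnc(N)c1C#N)c1nc2ccc(F)cc2n1-c1ccc(F)cc1`: 300 mL/min/kg
- compound 2 `C[C@H](Nc1ncnc(N)c1C#N)c1nc2ccc(F)cc2n1-c1cc(F)cc(F)c1`: 338 mL/min/kg

Compound 2 stands level with compound 1, as their two values lie within the scatter of each other. Compound 3 `C[C@H](Nc1ncnc(N)c1C#N)c1nc2ccc(F)cc2n1-c1ccccc1` differs from compound 2 by phenyl in place of 3,5-difluorophenyl on an aromatic nitrogen, leaving phenyl in place of 3,5-difluorophenyl on an aromatic nitrogen. Within the data shown here, one measured step bears on this change, since it altered the group on that same nitrogen: a 1.1-fold higher number from compound 1 to compound 2 (0.05 log units; within the scatter). On the strength of that step, no change beyond the scatter is expected in this assay, in either direction. The expected step is a 1.1-fold lower number from compound 2 to compound 3 (0.05 log units; within the scatter). Compound 3 is estimated at 300 mL/min/kg, within an expected range of 170 mL/min/kg to 520 mL/min/kg.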

Compound 3, clearance: 447 mL/min/kg
Compound 3: the middle estimate sits 1.5-fold (0.17 log units) below what was measured, and the stated range covers the measured number.
By their numbers in this assay, from the lowest: compounds 1, 2 and 3 (each within the scatter of the next).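

In this assay phenyl in place of 3,5-difluorophenyl on the aromatic nitrogen gives a 1.3-fold higher number from compound 2 to compound 3 (0.12 log units; within the scatter) and hydrogen in place of fluoro on an aromatic carbon gives a 1.5-fold higher number from compound 1 to compound 3 (0.17 log units; within the scatter) as well. Compound 3, with no fluoro on this ring, therefore stands level with both fluorinated compounds, so that none of the three groups on this nitrogen separates from the others beyond the scatter. No evidence given here explains these values. From the compounds shown here alone, it remains open whether a pyridyl ring or a methyl group on this nitrogen, or an amine on the phenyl ring, would shift the number beyond the scatter.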